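Pyrazolyl pyridine amides: ring-fused analogue for hepatocyte clearance

This account rests on a few compounds, and the source may have more. Where it says the series, first, only, none or still open, it means among the compounds named here.

Measured so far:
compound 1 `CC(=O)N[C@@H]1CCC[C@H](C(=O)Nc2cc(-c3cnc(C)n3C(C)C)ccn2)C1` — 7.4 uL/min
compound 2 `CC(=O)N[C@@H]1CCC[C@H](C(=O)Nc2cc(-c3cnn(C)c3C)c(Cl)cn2)C1` — 10 uL/min

Both compounds have been run in an ADME assay on cells (Hepatocyte, Rattus norvegicus) for metabolic stability, using equilibrium dialysis; on this read-out lower numbers stand for slow clearance and higher numbers for fast clearance. Compound 1 gives 7.4 uL/min and compound 2 gives 10 uL/min. Going by the values given here, of the two numbers, the one for compound 2 is the higher, but its gap to compound 1 lies within the scatter of repeat measurements and so does not set the two apart; both sit at the slow end of this read-out.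

Compound 3 `CC(=O)N[C@@H]1CCC[C@H](C(=O)Nc2cc(-c3cnn4c3CCC4)c(Cl)cn2)C1` is the next analogue and has not yet been measured. It differs from compound 2 in one place: a group of 8 heavy atoms (6 carbon, 2 nitrogen; one five-membered non-aromatic ring with 1 hetero atom, one five-membered aromatic ring with 2 hetero atoms) in place of a group of 7 heavy atoms (5 carbon, 2 nitrogen; one five-membered aromatic ring with 2 hetero atoms), on an aromatic carbon. The amide, the ring bearing the acetamide, and the chloro-substituted pyridine are kept.

Among the compounds with values here, no measured pair in this set tracks this kind of change, so the expectation rests only on the two values at hand, which lie close together. A small step, if any, is expected in this assay from compound 2 to compound 3, most likely toward a modestly higher number but not clearly beyond the scatter; the expected step is a 1.3-fold higher number from compound 2 to compound 3 (0.11 log units; within the scatter). Compound 3 is therefore estimated at 13 uL/min, with a likely range from 6 uL/min to 28 uL/min.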

Compound 3, intrinsic clearance in a liver preparation (reported as CLH), per the amount of preparation that the assay uses: 72 uL/min
Estimate against measurement, compound 3: 5.5-fold (0.74 log units) below, outside the stated range (above it).
By their numbers in this assay, from the lowest: compounds 1 and 2 (each within the scatter of the next); then compound 3.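

In this assay, the replacement of 1,5-dimethyl-1H-pyrazol-4-yl by the ring-fused group, on an aromatic carbon ortho to a chloro group, gives a 7.2-fold higher number from compound 2 to compound 3 (0.86 log units; beyond the scatter). This position is therefore not neutral for this read-out: a group of 8 heavy atoms in place of a group of 7 separates the two compounds clearly, although both groups have 0 hydrogen-bond donors, 2 hydrogen-bond acceptors and no net charge, and the amide, the ring bearing the acetamide and the chloro-substituted pyridine are kept. Nothing available bears on what lies behind this step.

A single step cannot tell whether the higher number follows the added five-membered non-aromatic ring itself or simply the extra carbon, and a 1-ethyl-5-methyl-1H-pyrazol-4-yl group, which has the same heavy-atom count as the entering group but no second ring, would separate these two readings. On these data alone, it is also open whether the same replacement has a comparable effect in a compound without the chloro group, so the step holds only for this one pair.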